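This account rests on a few compounds, and the source may have more. Where it says the series, first, only, none or still open, it means among the compounds named here.

Compound 1 `COc1ccc(C(O)(Cc2ccc(C)cc2)c2cccc3ccccc23)c(OC)c1OC` gives > 20000 nM, a limit of the assay rather than a number.
Compound 2 `COc1ccc(C(O)(Cc2ccc(F)cc2)c2cccc3ccccc23)c(OC)c1OC` gives 5860 nM.
Compound 3 `COc1ccc(/C(=C/c2ccc(F)cc2)c2cccc3ccccc23)c(OC)c1OC` gives 18900 nM.

These values come from a functional assay on THP-1 cells (Homo sapiens) for inhibition, read by sulforhodamine B assay, with a stated time of 48 h; on this read-out higher numbers stand for weaker inhibition and lower numbers for stronger inhibition. Compound 2 is the only one that gives a clear number. Compound 1 sits at a limit, (the limit of > 20000 nM in this assay, at which 1 of the 3 values shown sits). The change from compound 2 to compound 1 is methyl in place of fluoro on an aromatic carbon, and it made an at least 3.4-fold higher number from compound 2 to compound 1 (0.53 log units; beyond the scatter). Compound 3 shares the same change in the other part of the molecule with compound 2, but the difference between the two cores is not broken down here. Compound 4 `COc1ccc(/C(=C/c2ccc(C)cc2)c2cccc3ccccc23)c(OC)c1OC` is not yet measured; it differs from compound 3 by methyl in place of fluoro on an aromatic carbon, the same change as from compound 2 to compound 1. Going from compound 3 to compound 4, a step like the earlier one is expected, a 2.4-fold higher number from compound 3 to compound 4 (0.38 log units; beyond the scatter), resting on an at least 3.4-fold higher number from compound 2 to compound 1 (0.53 log units; beyond the scatter). For compound 4 an estimate of 45000 nM follows, between 15000 nM and 150000 nM, likely reported only as a limit.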

Compound 4, half-maximal inhibitory concentration: > 20000 nM
Compound 4 gave a limit, no number; the forecaster's own chance of this, stated with the estimate: 80%; the middle value does not contradict the limit.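

In this assay compound 4 gives > 20000 nM, which is a limit of the assay and not a number. The swap of fluoro for methyl on this core can therefore be read only as a floor, an at least 1.0-fold higher number from compound 3 to compound 4 (0.02 log units; that floor lies within the scatter), and the real step could be small or large. The data neither confirm nor rule out that the change carries over from one core to the other: the same change on two cores in this assay, an at least 3.4-fold higher number (0.53 log units; beyond the scatter) from compound 2 to compound 1 and an at least 1.0-fold higher number (0.02 log units; that floor lies within the scatter) from compound 3 to compound 4; the limit leaves it open whether they differ.

Going by these compounds, how far the value of compound 4 lies past the limit stays open. Also open, on these data alone, is what a chloro, a methoxy or an amine on the same aromatic carbon would give on either core.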